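The source may report more compounds than this note shows. Statements on the series, on what has been measured and on what is new or still open speak of the compounds shown alone.

In an ADME assay on ECV-304 cells (Homo sapiens) for cytotoxicity, read by MTT assay, with a stated time of 72 h (a higher number here means a weaker inhibitor, a lower number a stronger inhibitor), compound 3 (`COc1cc(C2=C(c3ccccc3)C(O[SiH2]C(C)(C)C)CC2=O)cc(OC)c1OC`) gives > 100 ug/mL, which is a limit and not a number. Compound 4 (`COc1cc(C2=C(c3cc(C)c(OC)c(C)c3)C(O[SiH2]C(C)(C)C)CC2=O)cc(OC)c1OC`) has 4-methoxy-3,5-dimethylphenyl in place of phenyl on a double-bonded ring carbon. Compound 1 (`COc1cc(C2=C(c3cc(C)c(OC)c(C)c3)C(O)CC2=O)cc(OC)c1OC`) already carries that group and gives > 100 ug/mL, also a limit. Compound 2 (`COc1cc(C2=C(c3cc(C)c(OC)c(C)c3)C(OC(C)=O)CC2=O)cc(OC)c1OC`) carries it too and gives > 100 ug/mL, again a limit. Going by the values given here, the only measured step, a step that the two limits leave unreadable from compound 1 to compound 2, offers no size to carry over. No clear change is expected, due to the limit of > 100 ug/mL in this assay, at which 3 of the 3 values shown sit. The expected step, a step that the limit leaves unreadable from compound 3 to compound 4, should therefore stay within the scatter. Compound 4 is estimated at 130 ug/mL, with an expected range of 60 ug/mL to 300 ug/mL, and will probably be reported only as a limit.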

Compound 4, half-maximal inhibitory concentration: 15 ug/mL
Compound 4: middle estimate off by 8.7-fold (0.94 log units), on the high side; the measured number lies below the stated range.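

In this assay, 4-methoxy-3,5-dimethylphenyl in place of phenyl brings an at least 6.6-fold lower number from compound 3 to compound 4 (0.82 log units; beyond the scatter). With that group kept, the silicon-bearing group on the oxygen brings an at least 6.6-fold lower number from compound 2 to compound 4 (0.82 log units; beyond the scatter) in place of acetyl and an at least 6.6-fold lower number from compound 1 to compound 4 (0.82 log units; beyond the scatter) in place of hydrogen. Only compound 4 carries both groups, and it alone gives a readable number, so at this position the effect of the aromatic group shows only alongside the silicon-bearing group. As far as these compounds go, how the methoxy and the two methyl groups share this change stays open. So does whether an amine or a carboxylic acid in the methoxy's place would keep it.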